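Imine series: 2-phenylethenyl replaces 4-chlorophenyl on compound 2

The compounds below may be only part of what the source reports. "The series", "measured", "known", "first", "only" and "open" are said of these compounds alone.

In an ADME assay on cells (Rhabdomyosarcoma cell, Homo sapiens) for cytotoxicity, read by MTT assay, with a stated time of 72 h (a higher number here means that more compound is tolerated, a lower number that less compound is tolerated), compound 2 `Clc1ccc(/C=N/c2sc3c(c2-c2nc4ccccc4s2)CCCC3)cc1` gives 367 ug/mL, the highest of the two numbers at hand. The nearest is compound 1 `Clc1ccccc1/C=N/c1sc2c(c1-c1nc3ccccc3s1)CCC2`, which in this assay gives 123 ug/mL, a gap beyond the scatter. Compound 3 `C(=C/c1ccccc1)\C=N\c1sc2c(c1-c1nc3ccccc3s1)CCCC2` differs from compound 2 by 2-phenylethenyl in place of 4-chlorophenyl on a carbon with a double bond to nitrogen. Among the compounds with values here, no pair of measured compounds shows this change, so the step cannot be read from the series. A modest step down is expected, a 1.8-fold lower number from compound 2 to compound 3 (0.26 log units; within the scatter), with wide uncertainty, as the two measured numbers already spread beyond the scatter. Compound 3 is expected at 200 ug/mL, within 80 ug/mL to 500 ug/mL.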

Compound 3, half-maximal cytotoxic concentration: 207 ug/mL
Compound 3: middle estimate off by 1.0-fold (0.01 log units), on the low side; the range from low to high includes it.
By their numbers in this assay, from the lowest: compounds 1, 3 and 2 (each within the scatter of the next, the first and the last beyond it).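

At the carbon with a double bond to nitrogen, the series now has its first readable step: in this assay, 2-phenylethenyl in place of 4-chlorophenyl gives a 1.8-fold lower number from compound 2 to compound 3 (0.25 log units; within the scatter), so this assay does not separate the two groups here. Both groups carry one six-membered aromatic ring of carbon only, and the place accepts either without a step beyond the scatter. No measurement on hand accounts for this result. Open, going by these compounds, is how the number responds at this place to a group without an aromatic ring, such as a longer alkyl chain, or to a phenyl ring bearing an amine or a carboxylic acid.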